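Ethoxy to methoxy on the shared core

The source may report more compounds than this note shows. Statements on the series, on what has been measured and on what is new or still open speak of the compounds shown alone.

In a functional assay on HeLa cells (Homo sapiens) for antiproliferative activity, read by MTT assay, with a stated time of 48 h (a lower number here means a stronger inhibitor, a higher number a weaker inhibitor), compound 1 (`COc1cc(-c2nnc3c(OC)cc(-c4ccc5[nH]ccc5c4)cn23)cc(OC)c1OC`) gives 85 nM while compound 2 (`CCOc1cc(-c2ccc3c(ccn3C)c2)cn2c(-c3cc(OC)c(OC)c(OC)c3)nnc12`) gives 210 nM as the higher number, a gap beyond the scatter. Compound 3 (`COc1cc(-c2nnc3c(OC)cc(-c4ccc5c(ccn5C)c4)cn23)cc(OC)c1OC`) differs from compound 2 by hydrogen in place of methyl on a saturated chain carbon bound to an oxygen on an aromatic ring in going from ethoxy to methoxy, hydrogen in place of methyl on a saturated chain carbon bound to an oxygen on an aromatic ring. Among the compounds with values here, no measured step isolates this change. In this assay a modest move to a lower number is expected, close to the scatter, since compound 1 also carries methoxy and gives 85 nM there. The expected step is a 1.8-fold lower number from compound 2 to compound 3 (0.24 log units; within the scatter) as estimated here. For compound 3 the estimate is 120 nM (expected range 45 nM to 320 nM).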

Compound 3, half-maximal inhibitory concentration: 15 nM
Estimate against measurement, compound 3: 8.0-fold (0.90 log units) above; measured number outside the range, below it.
By their numbers in this assay, from the lowest: compound 3; then compound 1; then compound 2.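

In this assay, ethoxy to methoxy on the shared core proves a large change at this position (a 14-fold lower number from compound 2 to compound 3 (1.15 log units; beyond the scatter)), so one methyl on a saturated chain carbon bound to an oxygen on an aromatic ring matters far more here than the earlier values suggested. With methoxy held, methyl in place of hydrogen on the aromatic nitrogen also lowers the number (a 5.7-fold lower number from compound 1 to compound 3 (0.75 log units; beyond the scatter)). No supporting data on hand account for either step.

On these data alone, whether a longer chain such as propoxy raises the number further remains open. So does the effect of ethyl on the aromatic nitrogen.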